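This account rests on a few compounds, and the source may have more. Where it says the series, first, only, none or still open, it means among the compounds named here.

Measured in an assay on isolated protein for inhibition of Aromatase (Homo sapiens), read by fluorescence, with stated times of 10 min and 60 min; a lower number here means a stronger inhibitor, a higher number a weaker inhibitor:
- compound 1 `O=C(c1ccc(O)cc1)c1cccc(Cn2ccnc2)c1`: 13 nM
- compound 2 `C#CCOc1ccc(C(=O)c2cccc(Cn3ccnc3)c2)cc1`: 650 nM
- compound 3 `COc1ccc(C(=O)c2cccc(Cn3ccnc3)c2)cc1`: 13 nM

Compound 3 stands level with compound 1 at the digits shown, together the lowest of the three numbers in this assay; the nearest neighbour is compound 1, no change at the digits printed from compound 1 to compound 3 (within the scatter), and the furthest is compound 2, a 50-fold lower number from compound 2 to compound 3 (1.70 log units; beyond the scatter).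

Compound 4 `CCC#CCOc1ccc(C(=O)c2cccc(Cn3ccnc3)c2)cc1` is not yet measured. It differs from compound 3 by but-1-yn-1-yl in place of hydrogen on a saturated chain carbon bound to an oxygen on an aromatic ring.

Among the measured compounds shown here, two measured steps bear on this. The step of a 50-fold higher number from compound 1 to compound 2 (1.70 log units; beyond the scatter) shows what adding the triple-bond chain on the ring oxygen costs, and the step of a 50-fold lower number from compound 2 to compound 3 (1.70 log units; beyond the scatter) shows the same thing read in reverse at the saturated chain carbon bound to the oxygen. The change to compound 4 adds a longer chain of the same kind at that carbon, so a large rise in this assay is expected, at least as large as seen before. Compound 4 is therefore estimated at 900 nM, range 150 nM to 5000 nM, the expected step being a 69-fold higher number from compound 3 to compound 4 (1.84 log units; beyond the scatter).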

Compound 4, half-maximal inhibitory concentration: 9 nM
Estimate against measurement, compound 4: 100-fold (2.00 log units) above; the whole stated range lies above it.
By their numbers in this assay, from the lowest: compounds 4, 1 and 3 (each within the scatter of the next); then compound 2.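

In this assay, the large loss seen with compound 2 does not extend to every triple-bond chain on the ring oxygen: ethyl in place of hydrogen on the triple-bonded carbon gives a 72-fold lower number from compound 2 to compound 4 (1.86 log units; beyond the scatter) and brings the series back to the level of the other two compounds, with a 1.4-fold lower number from compound 1 to compound 4 (0.16 log units; within the scatter) and a 1.4-fold lower number from compound 3 to compound 4 (0.16 log units; within the scatter) both printed as within the scatter. Among these four compounds, chain length alone therefore does not order the numbers, and compound 2 alone stands apart as the one with a hydrogen on the triple-bonded carbon. No supporting data are available to explain this difference.

A saturated pentyl chain on the ring oxygen would show whether the triple bond matters at all once the chain is this long. A longer chain beyond the triple bond, or an amine at its end, would show how much more this position accepts.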